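Anilide in place of cyclohexylamide on the shared core

The source may hold more compounds than are shown below. What is called first, only, known or untested is meant among the compounds shown, and "the series" means these compounds.

Measured so far, in a functional assay on SW480 cells (Homo sapiens) for cytotoxicity, read by MTT assay, with a stated time of 24 h; a higher number here means a weaker inhibitor, a lower number a stronger inhibitor:
- compound 1 `C=CC1=C(C(=O)NC2CCCCC2)C(c2ccc(OC)c(OC)c2)OC1`: 19100 nM
- compound 2 `C=CC1=C(C(=O)NCc2ccc(C)cc2)C(c2ccc(OC)cc2)OC1`: 31700 nM

Compound 1 gives the lower of the two numbers in this assay, but compound 2 sits within the usual scatter of it, so the two cannot be told apart on what has been measured.

Compound 3 `C=CC1=C(C(=O)Nc2ccccc2)C(c2ccc(OC)c(OC)c2)OC1` is not yet measured. It differs from compound 1 in one place: phenyl in place of cyclohexyl on an amide-type nitrogen. The rest of the shared core, including the dimethoxyphenyl group and the vinyl group, is kept unchanged.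

Among the compounds with values here, no step between measured compounds covers this kind of change, so nothing measured here tells how large it should be or in which direction. The step is therefore expected to be small, a 1.0-fold higher number from compound 1 to compound 3 (0.02 log units; within the scatter), and not beyond the scatter in either direction. Compound 3 is accordingly estimated at 20000 nM in this assay, with a range from 6000 nM to 60000 nM.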

Compound 3, half-maximal inhibitory concentration: 45100 nM
Compound 3: the middle estimate sits 2.3-fold (0.35 log units) below what was measured; the range from low to high includes it.
By their numbers in this assay, from the lowest: compounds 1, 2 and 3 (each within the scatter of the next, the first and the last beyond it).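

Putting phenyl in place of cyclohexyl on the amide-type nitrogen, with the dimethoxyphenyl and vinyl groups kept, gives a 2.4-fold higher number from compound 1 to compound 3 (0.37 log units; beyond the scatter) in this assay, so this position is not indifferent to which six-membered ring of carbon it carries. The two groups have the same count of heavy atoms and differ in the ring being aromatic or non-aromatic, and that one change makes compound 3 a modestly weaker inhibitor than compound 1. Nothing at hand speaks to what lies behind this step.

Within the data shown here, compound 2 differs from both compounds in more than one place, so it adds no step here. As far as these compounds go, it remains open how a pyridyl ring or a straight hexyl chain on the same nitrogen would compare, and whether the step holds with a different aryl group on the shared core.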